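Swapping an Amino Group for Ethoxy on the Core

The source may report more compounds than this note shows. Statements on the series, on what has been measured and on what is new or still open speak of the compounds shown alone.

Compound 2 `CC(C)=CCOc1cc(Nc2nccc(N)n2)ccc1Cl` gives the lower of the two values measured in an ADME assay on MT2 cells (Homo sapiens) for cytotoxicity (on this read-out lower numbers stand for higher toxicity in this test and higher numbers for lower toxicity in this test), at 500 nM; compound 1 `CC(C)=CCOc1cc(Nc2ncnc(Cl)n2)ccc1Cl` gives 45000 nM, and the step of a 90-fold lower number from compound 1 to compound 2 (1.95 log units; beyond the scatter). Compound 3 `CCOc1ccnc(Nc2ccc(Cl)c(OCC=C(C)C)c2)n1` differs from compound 2 in one place: ethoxy in place of amino on an aromatic carbon. Within the data shown here, no measured step changes the same part of the molecule in the same way; the single step available, from compound 1 to compound 2, exchanged a different group on the ring nitrogen and was large, so it sets only a rough scale. With nothing that directly tracks an amino-to-ethoxy swap, a moderate shift toward a higher number for compound 3 in this assay is expected, with real uncertainty, as a 4.0-fold higher number from compound 2 to compound 3 (0.60 log units; beyond the scatter). Compound 3 is therefore estimated at 2000 nM, within a range from 500 nM to 8000 nM.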

Compound 3, half-maximal cytotoxic concentration: 19000 nM
Compound 3: the middle estimate sits 9.5-fold (0.98 log units) below what was measured, and the stated range ends below it.
By their numbers in this assay, from the lowest: compound 2; then compound 3; then compound 1.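

This change touches a single group on an aromatic carbon next to the ring nitrogen, yet it gives a 38-fold higher number from compound 2 to compound 3 (1.58 log units; beyond the scatter) in this assay and so moves the number a long way. The earlier step exchanged the whole group on a nitrogen, whereas this one shows that the amino position alone matters strongly in this test. Nothing available explains why this swap has an effect of this size.

Ethoxy differs from amino in both its linking atom and its size, so the compounds shown cannot tell which of these goes with the higher number. Methoxy or methylamino at this position would help separate the two, and a longer chain such as propoxy would show whether the number keeps rising.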